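A few compounds are considered here, and "the series" means these few. Any claim that something is new, unique, unknown or untested is made for them only; others in the source may bear on it.

Within the data shown here, in a functional assay on A549 cells (Homo sapiens) for cytotoxicity, read by MTT assay, with a stated time of 72 h (on this read-out higher numbers stand for weaker inhibition and lower numbers for stronger inhibition), compound 1 `COc1ccc(/C=C2\CCC/C(=C\c3ccc(Br)cc3)C2=O)cc1OC` gives 16000 nM, the only exact number among the compounds measured so far. Compound 2 `COc1ccc(/C=C2\CCC/C(=C\c3ccc(O)cc3)C2=O)cc1OC` reports only a limit, > 20000 nM. Compound 3 `COc1ccc(/C=C2\CCC/C(=C\c3cccc(Cl)c3Cl)C2=O)cc1OC` also reports only a limit, > 20000 nM. Compound 3 therefore has no exact value and stands at the limit of > 20000 nM in this assay, at which 2 of the 3 values shown sit.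

Compound 4 `COc1ccc(/C=C2\CCC/C(=C\c3ccc(Cl)cc3Cl)C2=O)cc1OC` keeps the shared core and changes only the substituted phenyl group: 2,4-dichlorophenyl in place of 2,3-dichlorophenyl on a double-bonded chain carbon bound to a double-bonded ring carbon. In words, 2,4-dichlorophenyl takes the place of 2,3-dichlorophenyl on a double-bonded chain carbon bound to a double-bonded ring carbon.

Among the measured compounds shown here, three measured steps bear on this change, since each alters the same aromatic part. Putting 2,3-dichlorophenyl in place of 4-bromophenyl gives an at least 1.2-fold higher number from compound 1 to compound 3 (0.09 log units; that floor lies within the scatter). Putting hydroxy in place of bromo gives an at least 1.2-fold higher number from compound 1 to compound 2 (0.09 log units; that floor lies within the scatter). The remaining comparison is a step that the two limits leave unreadable from compound 2 to compound 3. None of these steps shows a change beyond the scatter, and compound 1 at 16000 nM gives the only exact reference point.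

No step beyond the scatter is therefore expected in this assay, and the expected change is a number no higher from compound 3 to compound 4 (the limit leaves the size open). The assay may well report only a limit again. For compound 4 the estimated value is 20000 nM, with an expected range from 9000 nM to 45000 nM.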

Compound 4, half-maximal inhibitory concentration: > 20000 nM
Compound 4 was reported as a limit; the forecaster's own chance of this, stated with the estimate: 55%; the middle value lies on the limit itself.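

Swapping 2,3-dichlorophenyl for 2,4-dichlorophenyl on this double-bonded chain carbon gives no readable change in this assay, and compound 4 reports only a limit, > 20000 nM. Among these compounds, the steps to compound 4 from compound 2 and from compound 3 cannot be read, since each joins two limits, and the one comparison with an exact number gives an at least 1.2-fold higher number from compound 1 to compound 4 (0.09 log units; that floor lies within the scatter). What is new is that both dichlorophenyl arrangements, in compound 3 and compound 4, now sit at the same limit, so neither gives an exact number at this position: the limit of > 20000 nM in this assay, at which 3 of the 4 values shown sit.

Among the compounds shown here, whether the two dichlorophenyl groups truly differ stays open, and so does whether any group at this position can give a number beyond the scatter from the only exact value, where compound 1 gives 16000 nM. A phenyl ring carrying an amine or a carboxylic acid, or a longer chain in place of the phenyl ring, would test this position with groups unlike the halogens and the hydroxy group shown here.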